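The source may report more compounds than this note shows. Statements on the series, on what has been measured and on what is new or still open speak of the compounds shown alone.

Compound 1 `Cc1c(OCCCCOc2ccc(C(=O)O)cc2F)ccc(C(=O)CC(C)C)c1O` gives 1420 nM in an assay on HEK293 cells for positive allosteric modulation of metabotropic glutamate receptor 3 (Rattus norvegicus), read by thallium flux, with a stated time of 2.5 min; a lower number here means that less compound is needed, a higher number that more compound is needed for the effect. Compound 2 `COC(=O)c1ccc(OCCCCOc2ccc(C(=O)CC(C)C)c(O)c2C)cc1` gives "not determined" (no result reported) in this assay, so compound 2 stands nowhere on that scale and offers no anchor of its own. Compound 3 `Cc1c(OCCCCOc2cccc(C(=O)O)c2)ccc(C(=O)CC(C)C)c1O` differs from compound 2 by 3-carboxyphenyl in place of 4-(methoxycarbonyl)phenyl on an oxygen on a saturated carbon. Going by the values given here, with no measured step to lean on, only a modest change in this assay can be expected, in either direction and probably not beyond the usual scatter, since compound 1 also carries a carboxy group and gives 1420 nM. Compound 3 is therefore estimated at 2000 nM, with a range from 500 nM to 8000 nM.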

Compound 3, half-maximal effective concentration: 1430 nM
The estimate for compound 3 lay 1.4-fold (0.15 log units) above the measured number, and the stated range covers the measured number.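

In this assay, putting 3-carboxyphenyl in place of 4-carboxy-2-fluorophenyl on an oxygen on a saturated carbon gives a 1.0-fold higher number from compound 1 to compound 3 (0.00 log units; within the scatter), so this position accepts either group without a readable change. That exchange alters both the place of the carboxy group and the presence of fluorine, and the compounds shown do not separate the two. Nothing available accounts for this result.

From the compounds shown here alone, whether the carboxy group itself matters stays open, as compound 2 provides no number for comparison. Going by these compounds, how a tetrazole or a primary amide in its place, or a longer chain, would read in this assay also remains unknown.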